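The source may report more compounds than this note shows. Statements on the series, on what has been measured and on what is new or still open speak of the compounds shown alone.

Measured compounds in an assay on CHO-K1 cells for displacement of a labelled ligand from Neuronal acetylcholine receptor; alpha4/beta2 (Homo sapiens), read by scintillation counting; on this read-out lower numbers stand for stronger inhibition and higher numbers for weaker inhibition:
- compound 1, `CN1[C@H](COc2cncc(Cl)c2)C[C@H]2C[C@H]21`: 0.37 nM
- compound 2, `CC(=O)N1[C@H](COc2ccc(Cl)nc2)C[C@H]2C[C@H]21`: > 10000 nM
- compound 3, `c1ccc(OC[C@@H]2C[C@H]3C[C@H]3N2)nc1`: > 10000 nM

Compound 2 stands at the edge of what this assay reports: its value of > 10000 nM is a limit of the assay, not a number. The same holds for compound 3, whose > 10000 nM is likewise only a limit. Only compound 1 returns a true number, and with 0.37 nM it sits far from that edge; this is the situation described by the limit of > 10000 nM in this assay, at which 2 of the 3 values shown sit.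

Compound 4, `CN1[C@H](COc2ccc(Cl)nc2)C[C@H]2C[C@H]21`, is compound 2 with one change: methyl in place of acetyl on an amine nitrogen in a ring. Among the compounds with values here, no pair of measured compounds differs in just this way, so the size of the step has to be judged from the surrounding compounds. Compound 1, which also carries a methyl on an amine nitrogen in a ring, gives 0.37 nM in this assay. Compound 2 with its acetyl sits at a limit. Compound 3, with neither group there and a different ether, sits at a limit as well, so the picture is not fully settled.

Nonetheless compound 4 is expected to move a long way towards stronger inhibition, well beyond the scatter, by a step of an at least 10000-fold lower number from compound 2 to compound 4 (4.00 log units; beyond the scatter). The estimate for compound 4 is 1 nM, expected to fall between 0.1 nM and 20 nM.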

Compound 4, inhibition constant: 3.4 nM
For compound 4 the middle estimate is 3.4-fold (0.53 log units) below the measured one; the measured number falls inside the stated range.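

In this assay, within the data shown here, exchanging acetyl for methyl on the amine nitrogen in the ring gives an at least 2900-fold lower number from compound 2 to compound 4 (3.46 log units; beyond the scatter), the first step that can be read between two compounds differing in one place. The rest of compound 4 is held as in compound 2, so the change on this nitrogen alone is enough to turn a read-out without a number into a true one, and compound 4 gives 3.4 nM. The step is only a bound and not an exact size, since compound 2 carries a limit and not a number: the limit of > 10000 nM in this assay, at which 2 of the 4 values shown sit.

Still open, from the compounds shown here alone, is whether this behaviour is particular to methyl or extends to ethyl, a longer chain or a plain hydrogen on the same nitrogen, since compound 3 carries that hydrogen but also has a different ether and so cannot settle the point. Equally open, going by these compounds, is how a sulfonyl group or a carbamate on this nitrogen would compare with acetyl, and whether the step from acetyl to methyl has a similar size with the ether of compound 1.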